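The source may report more compounds than this note shows. Statements on the series, on what has been measured and on what is new or still open speak of the compounds shown alone.

Measured so far:
Compound 1, `CC(C)S(=O)(=O)N1CCC(CN(C2Cc3cc(C#N)ccc3N(Cc3cncn3C)C2)S(=O)(=O)c2ccccn2)CC1` — 0.1 10^-6 cm/s
Compound 2, `Cn1cncc1CN1CC(N(CC2CCN(C(=O)N3CCCC3)CC2)S(=O)(=O)c2ccccn2)Cc2cc(C#N)ccc21` — 0.6 10^-6 cm/s

Among the measured compounds shown here, in an ADME assay on Caco-2 cells (Homo sapiens) for permeability, in the apical to basolateral direction (on this read-out higher numbers stand for higher permeability and lower numbers for lower permeability), compound 2 gives 0.6 10^-6 cm/s, the higher of the two numbers; the only neighbour is compound 1, which in this assay gives 0.1 10^-6 cm/s. For the measured compounds named here, the one step seen so far, a 6.0-fold higher number from compound 1 to compound 2 (0.78 log units; beyond the scatter), concerns the group on the ring amine nitrogen, not the carbonyl substituent that changes now. Compound 3, `Cn1cncc1CN1CC(N(CC2CCN(C(=O)Nc3ccc(Br)cc3)CC2)S(=O)(=O)c2ccccn2)Cc2cc(C#N)ccc21`, differs from compound 2 by (4-bromophenyl)amino in place of pyrrolidin-1-yl on a carbonyl carbon. Going by the values given here, no measured step bears directly on this change, so compound 3 is expected to stay near compound 2, with a step of a 1.2-fold lower number from compound 2 to compound 3 (0.08 log units; within the scatter) that is not expected to exceed the scatter. Compound 3 is therefore estimated at 0.5 10^-6 cm/s, with a range from 0.15 10^-6 cm/s to 2 10^-6 cm/s.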

Compound 3, apparent permeability: 0.6 10^-6 cm/s
Compound 3: middle estimate off by 1.2-fold (0.08 log units), on the low side; measured number inside the range.
By their numbers in this assay, from the lowest: compound 1; then compounds 2 and 3 (each within the scatter of the next).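

In this assay, replacing pyrrolidin-1-yl on the carbonyl carbon with (4-bromophenyl)amino, which brings an aromatic ring and a hydrogen-bond donor, gives no change at the digits printed from compound 2 to compound 3 (within the scatter). The rise seen on leaving isopropylsulfonyl thus appears with a second carbonyl group, as a 6.0-fold higher number from compound 1 to compound 3 (0.78 log units; beyond the scatter). Nothing available explains why these two carbonyl groups read alike.

Going by these compounds, it remains open whether an amine or a carboxylic acid in place of the bromine would leave the number unchanged. An open-chain dialkylamino group on the carbonyl carbon is also untested here.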